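Benzyl for cyclohexyl on a fused imidazole nitrogen

The source may hold more compounds than are shown below. What is called first, only, known or untested is meant among the compounds shown, and "the series" means these compounds.

Measured compounds:
compound 1, `c1ccc2c(-c3cn4ccnc4c(-c4ccc5ncn(C6CCCCC6)c5c4)n3)cccc2c1`, 17.9%
compound 2, `c1ccc(Cn2cnc3ccc(-c4nc(-c5cccc6ccccc56)cn5ccnc45)cc32)cc1`, 32.9%
compound 3, `c1cn2cc(-c3ccc4c(c3)ncn4C3CCCCC3)nc(-c3ccc4ncn(C5CCCCC5)c4c3)c2n1`, 29.1%

All three were tested in a functional assay on HCT-116 cells (Homo sapiens) for inhibition, read by sulforhodamine B assay, with a stated time of 48 h, tested at 10 uM; on this read-out lower numbers stand for less inhibition and higher numbers for more inhibition at the one concentration tested (going by the name of the read-out). Compound 1 carries two cyclohexyl groups on its imidazole nitrogens; compound 2 differs from it in one place, (benzyl in place of cyclohexyl on an aromatic nitrogen), and in this assay compound 2 reaches 32.9%. That step, a number 15 percentage points higher from compound 1 to compound 2 (beyond the scatter), is the only measured example of this change; among the compounds shown it occurs twice in all.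

Compound 3 has a core that is not the same as the core of compound 1; the difference between the two cores is not broken down here. In this assay compound 3 gives 29.1%, a number within the scatter of compound 2 and beyond the scatter of compound 1.

Compound 4, `c1ccc(Cn2cnc3ccc(-c4nc(-c5ccc6c(c5)ncn6C5CCCCC5)cn5ccnc45)cc32)cc1`, is not yet measured. It differs from compound 3 by benzyl in place of cyclohexyl on an aromatic nitrogen, the same change as from compound 1 to compound 2, at the same kind of place. Because the earlier step was a number 15 percentage points higher from compound 1 to compound 2 (beyond the scatter), the expected step from compound 3 to compound 4 is a number 12.9 percentage points higher from compound 3 to compound 4 (beyond the scatter), resting on that single precedent. Compound 4 is therefore estimated at 42%, between 28% and 56%.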

Compound 4, a percentage reported as inhibition, at one concentration (the size of the read-out at that concentration, not a potency): -75.8%
The estimate for compound 4 lay 117.8 percentage points above the measured number; measured number outside the range, below it.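

In this assay, benzyl in place of cyclohexyl on an aromatic nitrogen gave a number 104.9 percentage points lower from compound 3 to compound 4 (beyond the scatter) in this second example of the change. Two examples are too few to show which feature of the two cores goes with the difference, or how the change would behave on a third core. They do show that, in this series, a step measured on one core cannot safely be carried to another, as neither its size nor its direction held: the same change on two cores in this assay, a number 15 percentage points higher (beyond the scatter) from compound 1 to compound 2 and a number 104.9 percentage points lower (beyond the scatter) from compound 3 to compound 4, 119.9 percentage points apart, beyond the scatter of two such steps

The compounds shown leave open whether other groups on this aromatic nitrogen would behave as differently on the two cores as benzyl does. A longer chain such as phenethyl, or a benzyl ring carrying an amine or a carboxylic acid, could be compared on both cores in this assay to test whether this split between the cores is particular to benzyl.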